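Fixing One Stereocentre on Compound 3

The source may hold more compounds than are shown below. What is called first, only, known or untested is meant among the compounds shown, and "the series" means these compounds.

In a functional assay on A2780 cells (Homo sapiens) for antiproliferative activity (on this read-out lower numbers stand for stronger inhibition and higher numbers for weaker inhibition), compound 1 `Cc1ccc2c(c1C)CN(C(=O)N(C)C)CC2c1ccccc1` gives 1200 nM, compound 2 `Cc1ccc2c(c1C)CN(C(=O)N1CCCCC1)CC2c1ccccc1` gives 2830 nM and compound 3 `Cc1ccc2c(c1C)CN(C(=O)N(C)C)CC2c1cccc(O)c1` gives 376 nM, the lowest of the three numbers. Compound 4 `Cc1ccc2c(c1C)CN(C(=O)N(C)C)C[C@@H]2c1cccc(O)c1`, not yet measured, has the same atoms and bonds as compound 3: the two compounds have the same atoms and bonds; at least one stereo element is drawn with a configuration in one of them and without one in the other: 1 of 1 stereo elements differ; a stereocentre at a saturated ring carbon is drawn without a configuration in compound 3 and R in compound 4. Two measured steps show how far single changes have moved the number: a 2.4-fold higher number from compound 1 to compound 2 (0.37 log units; beyond the scatter) and a 3.2-fold lower number from compound 1 to compound 3 (0.50 log units; beyond the scatter). Both were modest, but both swap a group, so neither tests a stereocentre and they offer only a sense of scale. The expected change is therefore no step beyond the scatter, estimated as a 1.5-fold lower number from compound 3 to compound 4 (0.18 log units; within the scatter). For compound 4, the estimated value is 250 nM, with an expected range from 100 nM to 1200 nM.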

Compound 4, half-maximal inhibitory concentration: 234 nM
Compound 4: the middle estimate sits 1.1-fold (0.03 log units) above what was measured; measured number inside the range.
By their numbers in this assay, from the lowest: compounds 4 and 3 (each within the scatter of the next); then compound 1; then compound 2.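

Fixing this ring carbon as R swaps no group, unlike the two earlier steps, and in this assay it gives a 1.6-fold lower number from compound 3 to compound 4 (0.21 log units; within the scatter) and stays within the scatter. Compound 3 and compound 4 therefore cannot be separated by this read-out, and defining this centre as R shows no clear change. The pair can say only so much about configuration, and one fact sets that limit: the fact that one of compounds 3 and 4 is drawn with a defined configuration and the other without, at the place where they differ.

As far as these compounds go, what the S configuration at this carbon would give remains open. So does whether an amine or a carboxylic acid in place of the hydroxy group would hold the number.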